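The source may hold more compounds than are shown below. What is called first, only, known or untested is meant among the compounds shown, and "the series" means these compounds.

Measured compounds:
- compound 1 `O=C(/C=C/c1ccccc1)c1ccc(OCc2ccccc2)cc1O`: "not determined" (no result reported)
- compound 2 `COc1cc(O)c(C(=O)/C=C/c2ccccc2)cc1I`: "not determined" (no result reported)
- compound 3 `CCCOc1ccc(C(=O)/C=C/c2ccccc2)c(O)c1`: 16000 nM

For the measured compounds named here, in an ADME assay on BJ cells (Homo sapiens) for cytotoxicity, with a stated time of 48 h (on this read-out lower numbers stand for stronger inhibition and higher numbers for weaker inhibition), compound 3 gives 16000 nM and stands as the only compound with a number; compound 1 and compound 2 carry no result in this assay. The unmeasured compound 4 `CCOc1ccc(C(=O)/C=C/c2ccccc2)c(O)c1` differs from compound 3 by hydrogen in place of methyl on a saturated chain carbon, two bonds along the chain from an oxygen on an aromatic ring, a difference that reads propoxy to ethoxy when cut one bond further out. Going by the values given here, with no step between measured compounds to lean on, the change from compound 3 to compound 4 is expected to move this assay little, if at all, beyond the usual scatter, with the step of a 1.3-fold higher number from compound 3 to compound 4 (0.10 log units; within the scatter) estimated as close to none. Compound 4 is therefore expected to give about 20000 nM, within a range of 8000 nM to 50000 nM.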

Compound 4, half-maximal inhibitory concentration: 208000 nM
Compound 4: middle estimate off by 10-fold (1.02 log units), on the low side, and the stated range ends below it.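

For the compounds shown here, with a 13-fold higher number from compound 3 to compound 4 (1.11 log units; beyond the scatter) in this assay, this saturated chain carbon proves far from neutral, which no earlier compound could show: removing a single methyl, propoxy to ethoxy, is enough to weaken the read-out well beyond the scatter. The position therefore responds strongly to a small change in chain length. No available evidence accounts for the size of this step.

On these data alone, whether a longer chain such as butoxy would lower the number further remains open. So does the effect of an amine at the end of the chain.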